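The compounds below may be only part of what the source reports. "The series", "measured", "known", "first", "only" and "open" are said of these compounds alone.

Measured so far:
- compound 1, `Cc1nn(C2CCOCC2)cc1-c1nc2c(-c3ccc4c(c3)CCC[C@@H]4NC(=O)c3nc(C(C)(C)C)no3)ccnc2[nH]1`, with 1.3 10^-6 cm/s in an ADME assay on Caco-2 cells (Homo sapiens) for permeability, in the apical to basolateral direction; a lower number here means that the compound crosses the layer more slowly, a higher number that the compound crosses the layer faster
- compound 2, `Cc1c(-c2nc3c(-c4ccc5c(c4)CCC[C@@H]5NC(=O)c4nc(C(C)(C)C)no4)ccnc3[nH]2)cnn1C(C)C`, with 0.6 10^-6 cm/s in this assay

Among these two numbers compound 2 stands lowest: the step of a 2.2-fold lower number from compound 1 to compound 2 (0.34 log units; beyond the scatter) separates it from compound 1, and no other measured compound exists for comparison.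

Compound 3, `CC(C)n1cc(-c2nc3c(-c4ccc5c(c4)CCC[C@@H]5NC(=O)c4nc(C(C)(C)C)no4)ccnc3[nH]2)cn1`, has not yet been measured in this assay. It differs from compound 2 in a single place: hydrogen in place of methyl on an aromatic carbon. For the measured compounds named here, the only measured step, a 2.2-fold lower number from compound 1 to compound 2 (0.34 log units; beyond the scatter), concerns a different kind of change, namely a group of 9 heavy atoms in place of a group of 12 heavy atoms on an aromatic carbon, so it speaks to the size of the step to compound 3 only loosely. Removing a methyl is a smaller change than that swap, and nothing measured shows what it does here. The step of a 1.3-fold higher number from compound 2 to compound 3 (0.12 log units; within the scatter) is therefore expected to stay within the scatter, with a slight lean upward from the lowest value.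

For compound 3 the estimate in this assay is 0.8 10^-6 cm/s, expected to lie between 0.4 10^-6 cm/s and 1.6 10^-6 cm/s.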

Compound 3, apparent permeability in the Caco-2 assay: 2.6 10^-6 cm/s
Compound 3: middle estimate off by 3.3-fold (0.51 log units), on the low side; the measured number lies above the stated range.
By their numbers in the Caco-2 assay, from the lowest: compound 2; then compounds 1 and 3 (each within the scatter of the next).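

In the Caco-2 assay compound 2 gives 0.6 10^-6 cm/s and compound 3 gives 2.6 10^-6 cm/s: removing one methyl from an aromatic carbon, turning 1-isopropyl-5-methyl-1H-pyrazol-4-yl into 1-isopropyl-1H-pyrazol-4-yl, gives a 4.3-fold higher number from compound 2 to compound 3 (0.64 log units; beyond the scatter), so even this change moves the number beyond the scatter. The wider swap of the whole group on the core, which replaces 12 heavy atoms with 8, gives a 2.0-fold higher number from compound 1 to compound 3 (0.30 log units; within the scatter), so that pair cannot be told apart in this assay. In a physicochemical assay for solubility, in simulated intestinal fluid (a lower number here means a less soluble compound, a higher number a more soluble compound), compound 2 gives 28 ug/mL and compound 3 gives 25 ug/mL; the same methyl removal gives a 1.1-fold lower number from compound 2 to compound 3 (0.05 log units; within the scatter), so the change that registers clearly in the cell layer measurement leaves no readable mark on this second read-out.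

Nothing at hand explains why a single methyl makes this difference in the cell layer measurement. From the compounds shown here alone, it also remains open how the number would respond to a different group on this aromatic carbon, such as an ethyl, a chlorine or an amine, and whether removing a methyl would give a step of similar size with the group of compound 1 on the ring nitrogen.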